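Swapping the aryl group on an aromatic nitrogen

The compounds below may be only part of what the source reports. "The series", "measured", "known", "first", "only" and "open" are said of these compounds alone.

Compound 1, `COc1ccccc1-n1nncc1CN1C(=O)C2(C(C#N)=C(N)Oc3c2c2nc4ccccc4nc2c2ccccc32)c2ccccc21`: > 50000 nM
Compound 2, `CCOc1ccc(-n2nncc2CN2C(=O)C3(C(C#N)=C(N)Oc4c3c3nc5ccccc5nc3c3ccccc43)c3ccccc32)cc1`: > 50000 nM
Compound 3, `CCc1ccccc1-n1nncc1CN1C(=O)C2(C(C#N)=C(N)Oc3c(N)cc4nc5ccccc5nc4c32)c2ccccc21`: 10300 nM

In a functional assay on HCT-116 cells (Homo sapiens) for antiproliferative activity, read by MTT assay, with a stated time of 48 h (on this read-out lower numbers stand for stronger inhibition and higher numbers for weaker inhibition), compound 1 gives only a limit of the assay, > 50000 nM. Compound 2 likewise gives only a limit, > 50000 nM. Both of these rest at the limit of > 50000 nM in this assay, at which 2 of the 3 values shown sit. Among the compounds with values here, compound 3 is the single compound with a measured number, 10300 nM, so it stands as the only readable point among the three. Within the data shown here, the one change between measured compounds, a step that the two limits leave unreadable from compound 1 to compound 2, runs from one limit to another and therefore has no readable size.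

Compound 4, `N#CC1=C(N)Oc2c(N)cc3nc4ccccc4nc3c2C12C(=O)N(Cc1cnnn1-c1ccc([N+](=O)[O-])cc1)c1ccccc12`, differs from compound 3 by 4-nitrophenyl in place of 2-ethylphenyl on an aromatic nitrogen. Among the measured compounds shown here, no measured step concerns a swap of this kind on an aromatic nitrogen, and the single step between measured compounds cannot be read. With nothing to push the expectation either way, compound 4 is expected to stay close to compound 3, so the step of a 1.5-fold higher number from compound 3 to compound 4 (0.16 log units; within the scatter) is expected to lie within the usual scatter, with a fair chance that this assay reports only a limit. Compound 4 is estimated at 15000 nM, with a range from 4000 nM to 50000 nM.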

Compound 4, half-maximal inhibitory concentration: > 50000 nM
Compound 4: only a limit was reported; the forecaster's own chance of this, stated with the estimate: 40%; at least 3.3-fold (0.52 log units) between middle value and limit.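

In this assay, within the data shown here, the swap to 4-nitrophenyl in place of 2-ethylphenyl gives an at least 4.8-fold higher number from compound 3 to compound 4 (0.68 log units; beyond the scatter) and is the first change on this aromatic nitrogen with a readable size. Among these compounds, the earlier step at this position could not be read, so this is the first sign that the aryl group here can move the result beyond the usual scatter, and the move is towards weaker inhibition. Compound 4 gives only a limit and joins the compounds at that same limit: the limit of > 50000 nM in this assay, at which 3 of the 4 values shown sit.

On these data alone, it remains open whether the nitro group itself or the loss of the 2-ethylphenyl group accounts for the step, and a 4-ethylphenyl group on the same core would help separate the two. As far as these compounds go, whether a 4-aminophenyl group would keep the activity of compound 3 also stays open.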